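A Chlorophenyl Variant Awaiting Its Cytotoxicity Reading

A few compounds are considered here, and "the series" means these few. Any claim that something is new, unique, unknown or untested is made for them only; others in the source may bear on it.

compound 1 `O=c1c(O)c(-c2ccccc2)oc2cc(OCc3ccccc3[N+](=O)[O-])cc(O)c12` gives 32000 nM
compound 2 `N#Cc1cccc(COc2cc(O)c3c(=O)c(O)c(-c4ccccc4)oc3c2)c1` gives 72000 nM
compound 3 `O=c1c(O)c(-c2ccccc2)oc2cc(OCc3cccc([N+](=O)[O-])c3)cc(O)c12` gives 76000 nM

Of the compounds shown here, three have been measured in an ADME assay on Huh-5-2 cells (Homo sapiens) for cytotoxicity, read by WST assay, with a stated time of 3 days; a lower number here means that less compound is tolerated, a higher number that more compound is tolerated. Among them compound 3 has the highest number, but compound 2 lies close to it, the step of a 1.1-fold higher number from compound 2 to compound 3 (0.02 log units; within the scatter) falling within the scatter, so no order between these two can be read. The gap from compound 1 is wider: a 2.4-fold higher number from compound 1 to compound 3 (0.38 log units; beyond the scatter), and likewise a 2.3-fold higher number from compound 1 to compound 2 (0.35 log units; beyond the scatter).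

Compound 4 `O=c1c(O)c(-c2ccccc2)oc2cc(OCc3ccc(Cl)cc3)cc(O)c12` has not yet been measured. It differs from compound 3 in one place: 4-chlorophenyl in place of 3-nitrophenyl on a saturated chain carbon bound to an oxygen on an aromatic ring. Within the data shown here, none of the measured steps exchanges the group on that chain carbon for a chlorophenyl, so no step bears on it directly. What the set does show is that swapping one substituted phenyl for another on that carbon moved this assay by modest amounts at the most, the largest being a 2.4-fold higher number from compound 1 to compound 3 (0.38 log units; beyond the scatter), while the exchange of nitro for cyano, a 1.1-fold higher number from compound 2 to compound 3 (0.02 log units; within the scatter), produced nothing beyond the scatter. On that basis the step to compound 4 is expected to be small, a 1.4-fold lower number from compound 3 to compound 4 (0.14 log units; within the scatter), with no clear direction. Compound 4 is therefore estimated at 55000 nM, within a range from 20000 nM to 150000 nM.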

Compound 4, half-maximal cytotoxic concentration: > 100000 nM
Compound 4 ended at the assay's limit; the forecaster's own chance of this, stated with the estimate: 20%; middle value at least 1.8-fold (0.25 log units) away from the limit.
By their numbers in this assay, from the lowest: compound 1; then compounds 2 and 3 (each within the scatter of the next). At a limit, above all of these: compound 4.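

In this assay compound 4 gives > 100000 nM, which is a limit of the assay and not a number: the limit of > 100000 nM in this assay, at which 1 of the 4 values shown sits.

Among these compounds, the 4-chlorophenyl is the first group on this saturated chain carbon to carry neither a nitro nor a nitrile, and it still stands clear of the 2-nitrophenyl, with an at least 3.1-fold higher number from compound 1 to compound 4 (0.49 log units; beyond the scatter). That places compound 4 on the same side of compound 1 as the two groups measured earlier, so among these four compounds only the 2-nitrophenyl stands apart, though the steps of an at least 1.3-fold higher number from compound 3 to compound 4 (0.11 log units; that floor lies within the scatter) and an at least 1.3-fold higher number from compound 2 to compound 4 (0.14 log units; that floor lies within the scatter) do not separate the 4-chlorophenyl from the 3-nitrophenyl or the 3-cyanophenyl.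

How far compound 4 truly lies from compounds 2 and 3 stays open, and since the change from 3-nitrophenyl to 4-chlorophenyl alters both the substituent and where it sits on the ring, the compounds shown cannot tell these two apart. Nor do they show whether the number would hold with an amine or a carboxylic acid on that phenyl, or with a longer chain in place of the single carbon.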